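The compounds below may be only part of what the source reports. "The series", "measured", "known", "first", "only" and "open" are said of these compounds alone.

Among the compounds with values here, compound 2 `CN(C)CCn1cnnc1-c1cc(Oc2ccc(NC(=O)N/N=C/c3ccc(Cl)cc3)cc2F)ccn1` sits on the lower side of the two numbers so far in a functional assay on MKN-45 cells (Homo sapiens) for cytotoxicity, read by MTT assay, with a stated time of 72 h; on this read-out higher numbers stand for weaker inhibition and lower numbers for stronger inhibition: compound 2 gives 570 nM, while compound 1 `COc1ccc(/C=N/NC(=O)Nc2ccc(Oc3ccnc(-c4nncn4CCN(C)C)c3)c(F)c2)c(OC)c1OC` gives 2020 nM. Within the data shown here, the only step bearing on the benzylidene end of the series is a 3.5-fold lower number from compound 1 to compound 2 (0.55 log units; beyond the scatter), so varying this aryl group does move this assay, but no measured pair covers a change to a donor-bearing group there. Compound 3 `CN(C)CCn1cnnc1-c1cc(Oc2ccc(NC(=O)N/N=C/c3ccc(O)cc3)cc2F)ccn1` differs from compound 2 by hydroxy in place of chloro on an aromatic carbon, at the position described as para to a large group. Among the measured compounds shown here, with only the step from compound 1 to compound 2 as a guide, a change of roughly that size in either direction is plausible; a modest move back toward the number of compound 1 is taken as the central case, so compound 3 is expected at 1000 nM (range 400 nM to 3000 nM), an estimated step of a 1.8-fold higher number from compound 2 to compound 3 (0.24 log units; within the scatter).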

Compound 3, half-maximal inhibitory concentration: 820 nM
Beside the measured number, compound 3's estimate is 1.2-fold (0.09 log units) above it; the range from low to high includes it.
By their numbers in this assay, from the lowest: compounds 2 and 3 (each within the scatter of the next); then compound 1.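

In this assay, hydroxy in place of chloro on this aromatic carbon, para to a large group, gives a 1.4-fold higher number from compound 2 to compound 3 (0.16 log units; within the scatter), so this assay does not separate the 4-chlorophenyl and 4-hydroxyphenyl groups, although only hydroxy carries a hydrogen-bond donor. Within the data shown here, the 2,3,4-trimethoxyphenyl group stands apart from both: a 2.5-fold lower number from compound 1 to compound 3 (0.39 log units; beyond the scatter) joins a 3.5-fold lower number from compound 1 to compound 2 (0.55 log units; beyond the scatter), which places the only change beyond the scatter at this end of the series between compound 1 and the other two compounds. Nothing measured here accounts for these numbers.

On these data alone, whether an amine or a carboxylic acid on the same carbon would stay with compound 2 and compound 3 remains open. So does whether a single methoxy there would read like compound 1 or like the other two, which would show if the three methoxy groups act together.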